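Two sulfonamides at the assay limit, a third weighed

This account rests on a few compounds, and the source may have more. Where it says the series, first, only, none or still open, it means among the compounds named here.

Compound 1 `O=S(=O)(Nc1ccc2oc(-c3ccccc3)nc2c1)c1cccc(C(F)(F)F)c1` and compound 2 `CCc1ccc(S(=O)(=O)Nc2ccc3oc(-c4ccccc4)nc3c2)cc1` share a core and differ only in the ring carried on the sulfonyl sulfur. In an assay on isolated protein for inhibition of malate dehydrogenase, mitochondrial (Sus scrofa), with stated times of 45 min and 30 min (a higher number here means a weaker inhibitor, a lower number a stronger inhibitor), compound 1 gives only a limit, > 63000 nM, and no number. Compound 2 likewise gives only a limit in this assay, > 63000 nM. Among the compounds with values here, both values rest on (the limit of > 63000 nM in this assay, at which 2 of the 2 values shown sit), and no measured step between compounds 1 and 2 can be stated; compound 2 stands where every value shown here stands.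

Compound 3 `Cc1cccc(S(=O)(=O)Nc2ccc3oc(-c4ccccc4)nc3c2)c1` is the unmeasured member. It differs from compound 2 by 3-methylphenyl in place of 4-ethylphenyl on a sulfonyl sulfur. Within the data shown here, no step between measured compounds exists here, and the expectation for compound 3 leans only on the two limits: compound 1 and compound 2 carry different rings on the sulfonyl sulfur yet both sit at the limit of > 63000 nM in this assay, at which 2 of the 2 values shown sit, and the change to 3-methylphenyl is therefore expected to leave compound 3 near that limit, with no step beyond the scatter. The step that the limit leaves unreadable from compound 2 to compound 3 is expected to be small. Compound 3 is estimated at 80000 nM in this assay, within 30000 nM to 250000 nM, most likely returned again as a limit rather than a number.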

Compound 3, half-maximal inhibitory concentration: > 63000 nM
Compound 3 ended at the assay's limit; the forecaster's own chance of this, stated with the estimate: 85%; the middle value is on the limit's open side.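

Within the data shown here, compound 3, like compound 1 and compound 2, returned only a limit in this assay and no number, so no step from either of them to compound 3 can be read: the limit of > 63000 nM in this assay, at which 3 of the 3 values shown sit. The compounds shown leave open whether any ring on the sulfonyl sulfur would give a measurable value, and how these three compounds truly compare.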